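A few compounds are considered here, and "the series" means these few. Any claim that something is new, unique, unknown or untested is made for them only; others in the source may bear on it.

Compound 3 `O=S(=O)(c1cccc(F)c1)c1ccc2c(c1)CCC[C@H]2CN1CCCS1(=O)=O` gives 31.6 nM in an assay on isolated protein for displacement of a labelled ligand from 5-hydroxytryptamine receptor 6 (Homo sapiens) (a lower number here means a stronger inhibitor, a higher number a weaker inhibitor), the highest of the three numbers in hand. Compound 1 `Cn1ccc(S(=O)(=O)c2ccc3c(c2)CCC[C@H]3CN)c1` gives 7.94 nM and compound 2 `NC[C@@H]1CCCc2cc(S(=O)(=O)c3cc(F)cc4[nH]cnc34)ccc21` gives 5.01 nM, both lower than compound 3 by margins beyond the scatter. Compound 4 `CNC(=O)NC[C@@H]1CCCc2cc(S(=O)(=O)c3cccc(F)c3)ccc21` has not yet been measured in this assay. It differs from compound 3 in one place: a group of 5 heavy atoms (2 carbon, 2 nitrogen, 1 oxygen; no ring) in place of a group of 7 heavy atoms (3 carbon, 1 nitrogen, 2 oxygen, 1 sulfur; one five-membered non-aromatic ring with 2 hetero atoms), on a saturated chain carbon bound to a saturated ring carbon. Going by the values given here, no measured pair in this set isolates such a change, so the expectation rests on compound 3 alone, which with a group of no net charge at that place gives 31.6 nM. The step of a 1.3-fold higher number from compound 3 to compound 4 (0.10 log units; within the scatter) is expected to be small, within the scatter or slightly toward a higher number. Compound 4 is therefore estimated at 40 nM, with a range from 12 nM to 130 nM.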

Compound 4, inhibition constant: 0.398 nM
Compound 4: the middle estimate sits 100-fold (2.00 log units) above what was measured; the whole stated range lies above it.
By their numbers in this assay, from the lowest: compound 4; then compounds 2 and 1 (each within the scatter of the next); then compound 3.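

In this assay, putting (methylcarbamoyl)amino in place of the five-membered non-aromatic ring group gives a 79-fold lower number from compound 3 to compound 4 (1.90 log units; beyond the scatter), on a saturated chain carbon bound to a saturated ring carbon. This shows that the group at this place can shift the number strongly, even though both groups carry no net charge. No evidence on the cause of so large a step is in hand. The compounds shown leave open how an acetamide or an unsubstituted urea at this place would compare, and so which part of (methylcarbamoyl)amino carries the step.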